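The source may report more compounds than this note shows. Statements on the series, on what has been measured and on what is new or still open speak of the compounds shown alone.

Measured so far:
compound 1, `COC(C)(C)CCOc1cccc2ccc(N)nc12`: 132 nM
compound 2, `Nc1ccc2cccc(OCC3CCC3)c2n1`: 432 nM

In an assay on cells with melanin-concentrating hormone receptor 1 (Homo sapiens) as the target, read by radioligand binding (on this read-out lower numbers stand for stronger inhibition and higher numbers for weaker inhibition), compound 1 gives 132 nM and compound 2 gives 432 nM. Compound 2 thus stands with the higher of the two numbers, that is, the weaker inhibition. Within the data shown here, the only step known so far, a 3.3-fold higher number from compound 1 to compound 2 (0.51 log units; beyond the scatter), separates the two, and it came from a single change on a saturated chain carbon bound to an oxygen on an aromatic ring of the shared core.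

Compound 3, `CC(C)(C)CCOc1cccc2ccc(N)nc12`, has not yet been measured. It differs from compound 2 by neopentyl in place of cyclobutyl on a saturated chain carbon bound to an oxygen on an aromatic ring. The neopentyl group that enters resembles the 2-methoxy-2-methylpropyl group of compound 1, with the methoxy exchanged for a methyl, so the known step of a 3.3-fold higher number from compound 1 to compound 2 (0.51 log units; beyond the scatter) is the one that bears on it, read in the opposite direction. Partly reversing that step, compound 3 is expected to come out with a lower number in this assay than compound 2, a step of about a 2.4-fold lower number from compound 2 to compound 3 (0.38 log units; beyond the scatter). Compound 3 is estimated at 180 nM, with a range from 70 nM to 450 nM.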

Compound 3, half-maximal inhibitory concentration: 201 nM
The estimate for compound 3 lay 1.1-fold (0.05 log units) below the measured number; the range from low to high includes it.
By their numbers in this assay, from the lowest: compounds 1 and 3 (each within the scatter of the next); then compound 2.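

Compound 3 shows that the methoxy group of compound 1 is not needed for the number seen in this assay, since putting a methyl in its place gives a 1.5-fold higher number from compound 1 to compound 3 (0.18 log units; within the scatter) and leaves the two compounds indistinguishable here. It also shows that an open chain with no added oxygen can do better than the ring at this place, on a saturated chain carbon bound to an oxygen on an aromatic ring: neopentyl in place of cyclobutyl gives a 2.1-fold lower number from compound 2 to compound 3 (0.33 log units; beyond the scatter) and thus recovers much of the earlier loss. Among these three compounds, the two with a branched open chain both have lower numbers than the one with the ring, and none goes against that pattern.

This change removes a ring and also takes the group from 4 carbons to 5, so the compounds shown cannot say which of the two matters, nor how a longer chain or an amine at the chain end would read. Nothing available gives a reason for these differences.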